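Sulfonyl Group Added on the Ring Nitrogen of Compound 2

The source may report more compounds than this note shows. Statements on the series, on what has been measured and on what is new or still open speak of the compounds shown alone.

Measured so far:
compound 1 `COc1ccc(-c2c(Cl)c(=O)c3c(OC)cc(OC)cc3n2S(=O)(=O)c2ccc(OC)cc2)cc1`: 90000 nM
compound 2 `COc1ccc(-c2[nH]c3cc(OC)cc(OC)c3c(=O)c2I)cc1`: > 86200 nM

Of the compounds shown here, two share a core and have been tested in an ADME assay on BJ cells (Homo sapiens) for antiproliferative activity, with a stated time of 72 h; on this read-out higher numbers stand for an effect only at larger amounts of compound and lower numbers for an effect already at smaller amounts. Compound 1 `COc1ccc(-c2c(Cl)c(=O)c3c(OC)cc(OC)cc3n2S(=O)(=O)c2ccc(OC)cc2)cc1` carries a chloro group and a (4-methoxyphenyl)sulfonyl group on the ring nitrogen, and in this assay compound 1 gives 90000 nM, an effect seen only at large amounts. For compound 2 `COc1ccc(-c2[nH]c3cc(OC)cc(OC)c3c(=O)c2I)cc1` the assay reports no number but only a limit, > 86200 nM. This is the limit of > 86200 nM in this assay, at which 1 of the 2 values shown sits, so where compound 2 truly stands is not known beyond that edge.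

Compound 3 `COc1ccc(-c2c(I)c(=O)c3c(OC)cc(OC)cc3n2S(=O)(=O)c2ccc(OC)cc2)cc1` has not been measured. It differs from compound 2 by (4-methoxyphenyl)sulfonyl in place of hydrogen on an aromatic nitrogen. Among the compounds with values here, no measured pair shows this exact change, so its size cannot be read from the data. Within the data shown here, compound 1, the only measured compound bearing this sulfonyl group, gives 90000 nM, and compound 3 is therefore expected to remain in the same weak region, with the step from compound 2 to compound 3 estimated as a step that the limit leaves unreadable from compound 2 to compound 3, not beyond the scatter. Compound 3 is expected at 90000 nM, within 30000 nM to 300000 nM, and a limit rather than a number is quite possible.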

Compound 3, half-maximal effective concentration: > 34400 nM
Compound 3: only a limit was reported (the forecaster's own chance of this, stated with the estimate: 55%); the middle value is on the limit's open side.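

In this assay, compound 2 and compound 3 are reported only as limits, and neither the step from compound 2 to compound 3 nor the step from compound 1 to compound 3 can be read. The compounds shown leave open where compound 3 truly stands, and whether (4-methoxyphenyl)sulfonyl in place of hydrogen on an aromatic nitrogen, or iodo in place of chloro, changes the read-out at all.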